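Trifluoromethyl on the Benzyl Ring of a Urea Analogue

A few compounds are considered here, and "the series" means these few. Any claim that something is new, unique, unknown or untested is made for them only; others in the source may bear on it.

Of the compounds shown here, two have been measured in a functional assay on MGC-803 cells (Homo sapiens) for inhibition, read by MTT assay, with a stated time of 48 h; a higher number here means a weaker inhibitor, a lower number a stronger inhibitor. Compound 1 `Cc1ccc(NC(=S)NC(=O)c2ccc(OCc3ccc(Cl)cc3Cl)cc2)cc1-c1nc2ccccc2[nH]1` gives 3450 nM in this assay. Compound 2 `Cc1ccc(NC(=O)NC(=O)c2ccc(OCc3ccccc3)cc2)cc1-c1nc2ccccc2[nH]1` gives 39400 nM in this assay, the higher of the two numbers and beyond the scatter of compound 1. Among the measured compounds shown here, compound 1 and compound 2 differ in two places at once, so the two values show only that the pair spans a wide range, not which change carries it.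

Compound 3 `Cc1ccc(NC(=O)NC(=O)c2ccc(OCc3cccc(C(F)(F)F)c3)cc2)cc1-c1nc2ccccc2[nH]1` is unmeasured. It differs from compound 2 by trifluoromethyl in place of hydrogen on an aromatic carbon. No measured pair isolates this change, so the expectation for compound 3 rests on the fact that the substituted benzyl analogue compound 1 gives 3450 nM while the unsubstituted compound 2 gives 39400 nM, a difference that other changes may account for. A moderate step toward a lower number, a 2.0-fold lower number from compound 2 to compound 3 (0.29 log units; within the scatter), is expected, though a step within the scatter would not surprise. Compound 3 is therefore estimated at 20000 nM in this assay, with a plausible range from 6000 nM to 60000 nM.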

Compound 3, half-maximal inhibitory concentration: 13100 nM
Compound 3: the middle estimate sits 1.5-fold (0.18 log units) above what was measured, within the range that was stated.
By their numbers in this assay, from the lowest: compound 1; then compound 3; then compound 2.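

Among the compounds shown here, the step from the unsubstituted benzyl to the 3-(trifluoromethyl)benzyl group gives the first reading of a single change: in this assay, trifluoromethyl in place of hydrogen on an aromatic carbon, meta to a large group, gives a 3.0-fold lower number from compound 2 to compound 3 (0.48 log units; beyond the scatter). Compound 1 and compound 2 differ in two places at once and could not show this, whereas the new pair shows that this one change on the benzyl ring, with the rest of the urea analogue held fixed, moves the number by a modest amount beyond the scatter, and that the position takes the four heavy atoms of trifluoromethyl without a move toward a higher number. The data on hand offer nothing that would explain this step.

As far as these compounds go, whether a nitrile, a methoxy group or an amine at this same place would move the number as far remains open, as does the effect of trifluoromethyl elsewhere on the ring. Compound 1 differs from compound 3 in more than one place, so how much of its value comes from the thiourea and how much from the dichlorobenzyl group also remains unresolved.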